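Chlorobenzyl isomer step in the cyclic sulfonamide series

The source may hold more compounds than are shown below. What is called first, only, known or untested is meant among the compounds shown, and "the series" means these compounds.

Compound 1 `O=C1c2ccccc2N(Cc2ccccc2)S(=O)(=O)N1Cc1ccccc1` gives a limit in a functional assay on HEL cells (Homo sapiens) for inhibition; on this read-out lower numbers stand for higher toxicity in this test and higher numbers for lower toxicity in this test: > 200000 nM.
Compound 2 `O=C1c2ccccc2N(Cc2ccccc2Cl)S(=O)(=O)N1Cc1ccccc1` gives 88000 nM in this assay.

Within the data shown here, compound 2 holds the only number measured so far in this assay; the value for compound 1 is a limit, not a number, as the entry the limit of > 200000 nM in this assay, at which 1 of the 2 values shown sits, shows. Among the measured compounds shown here, the single measured step, an at least 2.2-fold lower number from compound 1 to compound 2 (0.35 log units; beyond the scatter), is the change from chloro to hydrogen on an aromatic carbon and is read against that limit, so its true size is open at the top.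

Compound 3 `O=C1c2ccccc2N(Cc2ccc(Cl)cc2)S(=O)(=O)N1Cc1ccccc1` differs from compound 2 in one place: 4-chlorophenyl in place of 2-chlorophenyl on a saturated chain carbon bound to a sulfonamide nitrogen in a ring. For the measured compounds named here, this moves the chlorine within the chlorobenzyl group rather than adding or removing it, so no measured step speaks to it directly. The step of an at least 2.2-fold lower number from compound 1 to compound 2 (0.35 log units; beyond the scatter) only shows that a chlorine on this group is compatible with a number inside the range of this assay. In the absence of a comparable step, no change beyond the scatter is expected, with a wide range in both directions.

The expected value for compound 3 in this assay is 80000 nM, between 30000 nM and 200000 nM. This expectation corresponds to a step of a 1.1-fold lower number from compound 2 to compound 3 (0.04 log units; within the scatter).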

Compound 3, half-maximal cytotoxic concentration: > 200000 nM
Compound 3 was reported as a limit (the forecaster's own chance of this, stated with the estimate: 25%); at least 2.5-fold (0.39 log units) between middle value and limit.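

Moving the chlorine, 2-chlorobenzyl to 4-chlorobenzyl on a saturated chain carbon bound to a sulfonamide nitrogen in a ring, gives an at least 2.2-fold higher number from compound 2 to compound 3 (0.35 log units; beyond the scatter) in this assay; on this group, the place of the chlorine makes a difference beyond the scatter, which the addition of chlorine in the earlier step could not show. Compound 3 is reported as a limit and not a number, and the size of this step is open at the top, while the step between the two limit compounds cannot be read. Within these three compounds, only compound 2 gives a number, 88000 nM. Compound 1 and compound 3 share one limit: the limit of > 200000 nM in this assay, at which 2 of the 3 values shown sit.

Whether the lower number of compound 2 depends on chlorine itself remains open, since fluoro, methoxy or nitrile in place of the chloro of 2-chlorophenyl are not among the compounds shown. Also open, on these data alone, is how an amine or a carboxylic acid on this benzyl group would read in this assay, and whether any change to the second benzyl group would shift these numbers.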